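The source may hold more compounds than are shown below. What is called first, only, known or untested is meant among the compounds shown, and "the series" means these compounds.

Of the compounds shown here, three built on one shared core have been tested in a functional assay on MKN-74 cells (Homo sapiens) for antiproliferative activity, with a stated time of 24 h; on this read-out lower numbers stand for stronger inhibition and higher numbers for weaker inhibition. Compound 1 `NC(=O)c1c(NC(=O)c2ccccc2I)sc2c1CCN(C(=S)Nc1ccccc1Cl)C2` gives 17500 nM. Compound 2 `COc1ccccc1C(=O)Nc1sc2c(c1C(N)=O)CCN(C(=S)Nc1ccccc1Cl)C2` gives 20500 nM, and compound 3 `NC(=O)c1c(NC(=O)c2cccc([N+](=O)[O-])c2)sc2c1CCN(C(=S)Nc1ccccc1Cl)C2` gives 8850 nM. Of these three numbers compound 1 holds the second highest: the step of a 1.2-fold higher number from compound 1 to compound 2 (0.07 log units; within the scatter) is small, and the step of a 2.0-fold lower number from compound 1 to compound 3 (0.30 log units; within the scatter) is also small, while the step of a 2.3-fold lower number from compound 2 to compound 3 (0.36 log units; beyond the scatter) is the only one that reaches beyond the scatter, and even that only modestly.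

Compound 4 `NC(=O)c1c(NC(=O)c2ccccc2I)sc2c1CCN(C(=S)Nc1ccccc1C(F)(F)F)C2` is the next compound to consider. Its difference from compound 1 is trifluoromethyl in place of chloro on an aromatic carbon. Among the compounds with values here, every measured step so far altered the ring attached to the carbonyl carbon; none altered the ring that carries the chloro, so no measured step bears directly on this change. What the three measured compounds do show is that swapping substituents around the core moves this read-out by small amounts only. On that basis the step from compound 1 to compound 4 is expected to be a 1.2-fold lower number from compound 1 to compound 4 (0.07 log units; within the scatter), with no firm direction. Compound 4 is therefore estimated at 15000 nM in this assay, with a likely range from 6000 nM to 40000 nM.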

Compound 4, half-maximal inhibitory concentration: 14200 nM
Compound 4: middle estimate off by 1.1-fold (0.02 log units), on the high side; the range from low to high includes it.
By their numbers in this assay, from the lowest: compounds 3, 4, 1 and 2 (each within the scatter of the next, the first and the last beyond it).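

Within the data shown here, this is the first measured change on the ring that carries the chloro rather than on the ring attached to the carbonyl carbon, and in this assay the step reads a 1.2-fold lower number from compound 1 to compound 4 (0.09 log units; within the scatter). On this read-out compound 1 and compound 4 cannot be told apart, so at this place, on an aromatic carbon ortho to a large group, trifluoromethyl can stand in for chloro although it has more heavy atoms, at least in this one pair, where the 2-iodophenyl group stays on the carbonyl carbon. No supporting measurement is available that could explain why the two groups give such similar numbers.

This single pair cannot show whether the same swap would behave alike with the 3-nitrophenyl group of compound 3 or the 2-methoxyphenyl group of compound 2 on the carbonyl carbon. It also leaves open whether this place tolerates groups of a quite different kind, such as an amine, a carboxylic acid or a longer chain, or whether the number would move with one of those in place of chloro or trifluoromethyl.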